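Chalcone anilides: furan-2-yl in place of 4-chlorophenyl

The source may report more compounds than this note shows. Statements on the series, on what has been measured and on what is new or still open speak of the compounds shown alone.

Measured so far:
compound 1, `O=C(CO[N+](=O)[O-])Nc1ccc(C(=O)/C=C/c2ccco2)cc1`: 34%
compound 2, `C/C(=N/O)c1ccc(OCC(=O)Nc2ccc(C(=O)/C=C/c3ccc(Cl)cc3)cc2)cc1`: 39%

Both numbers come from a functional assay on the whole organism (strain albino) for inhibition, with Rattus norvegicus as the target, read by paw edema, with stated times of 30 min and 1 h, at a dose of 100 mg/kg by the oral route; on this read-out lower numbers stand for less inhibition and higher numbers for more inhibition at the one dose given (going by the name of the read-out). Compound 2 stands as the higher of the two numbers, but the number for compound 1 lies within the scatter of it, so the two compounds are not distinguished on this read-out. Compound 3 `C/C(=N/O)c1ccc(OCC(=O)Nc2ccc(C(=O)/C=C/c3ccco3)cc2)cc1` has not yet been measured. Against compound 2 the difference is furan-2-yl in place of 4-chlorophenyl on a double-bonded chain carbon bound to a double-bonded chain carbon. For the measured compounds named here, no step between measured compounds isolates this change; compound 1 already carries the furan-2-yl group, together with a different amide, and its value does not separate from that of compound 2. The step of a number 4 percentage points lower from compound 2 to compound 3 (within the scatter) is expected to stay within the scatter, with no clear direction. Compound 3 is estimated at 35%, with a range from 24% to 46%.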

Compound 3, a percentage reported as inhibition, in the whole organism at one dose (the size of the read-out at that dose, not a potency): 36%
Compound 3: the middle estimate sits 1 percentage points below what was measured, within the range that was stated.
By their numbers in this assay, from the lowest: compounds 1, 3 and 2 (each within the scatter of the next).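

In this assay the exchange of 4-chlorophenyl for furan-2-yl on a double-bonded chain carbon bound to a double-bonded chain carbon now stands as a step of its own (a number 3 percentage points lower from compound 2 to compound 3 (within the scatter)), so the two rings are not distinguished at this position at the one dose given. With furan-2-yl held in place, a group of 10 heavy atoms in place of a group of 3 heavy atoms on an oxygen on a saturated carbon (a number 2 percentage points higher from compound 1 to compound 3 (within the scatter)) is not distinguished either. Nothing on hand offers an explanation for these results.

Going by these compounds, how a cyclohexyl group or a 4-aminophenyl group would read at this position stays open. On these data alone, with a single dose and all three numbers within the scatter of their neighbours, any difference in potency among the compounds also stays open.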